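Moving the Chlorine Around the Phenyl Ring

The source may hold more compounds than are shown below. What is called first, only, known or untested is meant among the compounds shown, and "the series" means these compounds.

compound 1 `O=C(NC(c1ccc2ccccc2c1)C1CCNCC1)c1ccc2cnccc2c1`: 400 nM
compound 2 `O=C(NC(c1cccc(Cl)c1)C1CCNCC1)c1ccc2cnccc2c1`: 70 nM

Going by the values given here, in an assay on isolated protein for inhibition of RAC-alpha serine/threonine-protein kinase (Homo sapiens) (a lower number here means a stronger inhibitor, a higher number a weaker inhibitor), compound 2 has the lower of the two numbers; the only measured step is a 5.7-fold lower number from compound 1 to compound 2 (0.76 log units; beyond the scatter). Compound 3, `O=C(NC(c1ccc(Cl)cc1)C1CCNCC1)c1ccc2cnccc2c1`, differs from compound 2 in that (4-chlorophenyl in place of 3-chlorophenyl on a saturated chain carbon bound to an amide-type nitrogen and a saturated ring carbon). That single measured step swapped the entire aromatic group at this position, whereas here only the chlorine changes place, so it offers just a loose guide. A step in this assay no larger than the scatter is expected, in either direction. Compound 3 is estimated at 100 nM (range 30 nM to 350 nM), which is expected to mean a 1.4-fold higher number from compound 2 to compound 3 (0.15 log units; within the scatter).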

Compound 3, half-maximal inhibitory concentration: 190 nM
The estimate for compound 3 lay 1.9-fold (0.28 log units) below the measured number, and the stated range covers the measured number.
By their numbers in this assay, from the lowest: compound 2; then compound 3; then compound 1.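

The place of the chlorine on the phenyl ring matters in this assay, even though the atoms stay the same (a 2.7-fold higher number from compound 2 to compound 3 (0.43 log units; beyond the scatter)). The 4-chlorophenyl group still gives a lower number than naphthalen-2-yl (a 2.1-fold lower number from compound 1 to compound 3 (0.32 log units; beyond the scatter)), so compound 2, with 3-chlorophenyl, stands lowest of the three. Nothing available here explains why moving the chlorine changes the number.

Still open, as far as these compounds go, is how a plain phenyl group would compare at this carbon. It is also unknown whether a methoxy group in place of the chlorine would show the same dependence on ring position.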